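The source may report more compounds than this note shows. Statements on the series, on what has been measured and on what is new or still open speak of the compounds shown alone.

Measured so far:
compound 1 `COc1cccc(OC/C=C(\C)CC/C=C(\C)C2CC(=O)C(C)(C)O2)c1` — 33.8 ug/mL
compound 2 `C/C(=C\COc1c(Cl)cccc1Cl)CC/C=C(\C)C1=CC(=O)C(C)(C)O1` — 27.4 ug/mL

In a functional assay (Homo sapiens) for inhibition (a lower number here means a stronger inhibitor, a higher number a weaker inhibitor), compound 2 gives 27.4 ug/mL, the lowest of the two numbers, with compound 1 within the scatter of it. Compound 3 `COc1cccc(OC/C=C(\C)CC/C=C(\C)C2=CC(=O)C(C)(C)O2)c1` has not yet been measured. It differs from compound 2 by 3-methoxyphenyl in place of 2,6-dichlorophenyl on an oxygen on a saturated carbon. For the measured compounds named here, with only two values in hand, both close together, there is no guide for how this exchange moves the read-out, so the writer expects no step beyond the scatter, the estimated step being a 1.1-fold higher number from compound 2 to compound 3 (0.04 log units; within the scatter). Compound 3 is therefore expected to give about 30 ug/mL, in the range 12 ug/mL to 75 ug/mL.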

Compound 3, half-maximal inhibitory concentration: 35.9 ug/mL
For compound 3 the middle estimate is 1.2-fold (0.08 log units) below the measured one, within the range that was stated.
By their numbers in this assay, from the lowest: compounds 2, 1 and 3 (each within the scatter of the next).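

In this assay, 3-methoxyphenyl in place of 2,6-dichlorophenyl on an oxygen on a saturated carbon gives a 1.3-fold higher number from compound 2 to compound 3 (0.12 log units; within the scatter), so at this position the two aromatic groups cannot be told apart. For the compounds shown here, exchanging one five-membered non-aromatic ring group for the other, on a double-bonded chain carbon, gives a 1.1-fold higher number from compound 1 to compound 3 (0.03 log units; within the scatter), so that exchange cannot be told apart from no step either. Nothing available explains these results. As far as these compounds go, whether an amine or a carboxylic acid in place of 3-methoxyphenyl would give a step beyond the scatter remains open.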